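Replacing morpholin-4-yl in compound 2

The source may report more compounds than this note shows. Statements on the series, on what has been measured and on what is new or still open speak of the compounds shown alone.

In a functional assay on MCF7 cells (Homo sapiens) for antiproliferative activity, read by sulforhodamine B assay, with a stated time of 48 h (on this read-out higher numbers stand for weaker inhibition of growth and lower numbers for stronger inhibition of growth), compound 1 `CCCCCC[C@@H](O)C/C=C\CCCCCCCC(=O)N[C@@H](C)c1ccccc1` gives 5.1 ug/mL and compound 3 `CCCCCCCC/C=C\CCCCCCCC(=O)N1CCCC1` gives 5.2 ug/mL as values within the scatter of each other. Compound 2 `CCCCCCCCCCCCCCCCCC(=O)N1CCOCC1` gives 42.8 ug/mL as the highest of the three numbers and stands beyond the scatter from both others.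

Compound 4 `CCCCCCCCCCCCCCCCCC(=O)N[C@H](C)c1ccccc1` has no number yet and differs from compound 2 in one place ((1-phenylethyl)amino in place of morpholin-4-yl on a carbonyl carbon). The change puts (1-phenylethyl)amino in place of morpholin-4-yl on a carbonyl carbon. Among the measured compounds shown here, no measured pair isolates this change. Compound 1 also carries (1-phenylethyl)amino, on a different chain, and at 5.1 ug/mL it points toward a lower number for compound 4. The data do not separate the chain from the amide part, so only part of that gap is expected to carry over.

In this assay the expected change is a 2.9-fold lower number from compound 2 to compound 4 (0.46 log units; beyond the scatter) toward stronger inhibition of growth, an estimated step beyond the scatter. Compound 4 is expected at 15 ug/mL within a range of 5 ug/mL to 45 ug/mL as the working estimate.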

Compound 4, concentration for 50% growth inhibition: 0.06 ug/mL
Beside the measured number, compound 4's estimate is 250-fold (2.40 log units) above it, and the stated range ends above it.
By their numbers in this assay, from the lowest: compound 4; then compounds 1 and 3 (each within the scatter of the next); then compound 2.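

With the saturated chain held constant, the group on the carbonyl carbon matters strongly in this assay: (1-phenylethyl)amino in place of morpholin-4-yl gives a 710-fold lower number from compound 2 to compound 4 (2.85 log units; beyond the scatter) as a large step toward stronger inhibition of growth. Among the compounds shown here, this is the only measured pair that isolates this change, whereas the earlier compounds left the chain and the amide part unseparated. The change brings in an aromatic ring, a hydrogen-bond donor and a defined stereocentre together, and no supporting data tie the step to any one of them.

Which of these parts carries the step remains open: benzylamino, without the methyl, and piperidin-1-yl, a saturated ring without the oxygen, would divide it. Going by these compounds, the opposite stereocentre of (1-phenylethyl)amino on this chain also remains open.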